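The compounds below may be only part of what the source reports. "The series", "measured", "known", "first", "only" and "open" are said of these compounds alone.

Working notes on the series. The compounds share one core, carrying a varied aryl group on the nitrogen of that core. Compound 1 `Cn1ccc2c(Oc3ccc(NC(=O)c4cc5cccnc5n(-c5ccc(Cl)cc5)c4=O)cc3)ccnc21` carries a chloro-substituted phenyl there; in a functional assay on NCI-H460 cells (Homo sapiens) for antiproliferative activity, read by MTT assay, with a stated time of 72 h (a higher number here means a weaker inhibitor, a lower number a stronger inhibitor), compound 1 stands at "not determined" (no result reported). Compound 2 `Cn1ccc2c(Oc3ccc(NC(=O)c4cc5cccnc5n(-c5ccc(Br)cc5F)c4=O)cc3)ccnc21` carries a bromo- and fluoro-substituted phenyl; in this assay compound 2 likewise stands at "not determined" (no result reported), so no number anchors it. Going by the values given here, compound 3 `Cn1ccc2c(Oc3ccc(NC(=O)c4cc5cccnc5n(-c5ccc(C(F)(F)F)cc5Cl)c4=O)cc3)ccnc21` carries a trifluoromethyl- and chloro-substituted phenyl, and in this assay compound 3 gives 6950 nM, the only number in the set.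

Compound 4 `Cn1ccc2c(Oc3ccc(NC(=O)c4cc5cccnc5n(-c5ccc(Br)cc5F)c4=O)cc3F)ccnc21` differs from compound 2 by fluoro in place of hydrogen on an aromatic carbon, on an aromatic carbon of a six-membered aromatic ring of carbon only, in the linker part of the molecule. Among the compounds with values here, no measured pair shows what such a change does here, so no size or direction of step in this assay can be read off; nothing beyond the scatter is assumed.

With compound 3 at 6950 nM as the sole reference point, compound 4 is expected to land near 5000 nM in this assay, with a wide range from 800 nM to 30000 nM.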

Compound 4, half-maximal inhibitory concentration: 3150 nM
Estimate against measurement, compound 4: 1.6-fold (0.20 log units) above; low and high end bracket the measured number.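

In this assay, going by these compounds alone, compound 2 stands at "not determined" (no result reported), so no step to compound 4 can be read. The compounds shown leave open what fluoro in place of hydrogen on the linker's aromatic ring does to this activity. No evidence bears on this result.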